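From tert-butyl to bromo on the aromatic ring

A few compounds are considered here, and "the series" means these few. Any claim that something is new, unique, unknown or untested is made for them only; others in the source may bear on it.

Measured so far in a functional assay on A549 cells (Homo sapiens) for cytotoxicity, read by MTT assay, with a stated time of 48 h; on this read-out lower numbers stand for stronger inhibition and higher numbers for weaker inhibition:
- compound 1 `CC1(C)CCC[C@]2(C)[C@@H](CC[C@@](C)(O)/C=C/c3cncc4ccccc34)[C@](C)(O)CC[C@@H]12`: 45700 nM
- compound 2 `CC1(C)CCC[C@]2(C)[C@@H](CC[C@@](C)(O)/C=C/c3ccc(Cl)nc3)[C@](C)(O)CC[C@@H]12`: 3280 nM
- compound 3 `CC(C)(C)c1ccc(/C=C/[C@](C)(O)CC[C@@H]2[C@@]3(C)CCCC(C)(C)[C@@H]3CC[C@@]2(C)O)cc1`: 45000 nM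

Compound 3 stands at the high end of these numbers, level with compound 1: a 1.0-fold lower number from compound 1 to compound 3 (0.01 log units; within the scatter) lies within the scatter. Compound 2 sits well apart, and a 14-fold higher number from compound 2 to compound 3 (1.14 log units; beyond the scatter) is a large step beyond the scatter.

Compound 4 `CC1(C)CCC[C@]2(C)[C@@H](CC[C@@](C)(O)/C=C/c3ccc(Br)cc3)[C@](C)(O)CC[C@@H]12` has bromo in place of tert-butyl on an aromatic carbon, para to a large group (bromo in place of tert-butyl on an aromatic carbon). Among the compounds with values here, no measured step makes this exact swap. Within the data shown here, the nearest guide is compound 2, the only measured compound with a halogen on its ring, as a 14-fold higher number from compound 2 to compound 3 (1.14 log units; beyond the scatter) shows. That ring also differs in other ways, so only part of that step is expected to carry over. Meanwhile, a 1.0-fold lower number from compound 1 to compound 3 (0.01 log units; within the scatter) shows that a different ring need not move the number. A moderate fall is therefore expected in this assay. The expected step is a 3.0-fold lower number from compound 3 to compound 4 (0.48 log units; beyond the scatter). For compound 4 the estimated value is 15000 nM, with an expected range from 4000 nM to 50000 nM.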

Compound 4, half-maximal inhibitory concentration: 43200 nM
The estimate for compound 4 lay 2.9-fold (0.46 log units) below the measured number; the range from low to high includes it.
By their numbers in this assay, from the lowest: compound 2; then compounds 4, 3 and 1 (each within the scatter of the next).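

In this assay, bromo, with its single heavy atom, and tert-butyl, with its four, give matching numbers on this aromatic carbon, para to a large group: a 1.0-fold lower number from compound 3 to compound 4 (0.02 log units; within the scatter). A halogen on this six-membered aromatic ring of carbon only therefore does not bring compound 4 level with compound 2, as a 13-fold higher number from compound 2 to compound 4 (1.12 log units; beyond the scatter) remains a large step, while a 1.1-fold lower number from compound 1 to compound 4 (0.02 log units; within the scatter) places compound 4 level with compound 1. No supporting evidence bears on this result, so the data offer no explanation of it.

On these data alone, it remains open whether an amine or a carboxylic acid on this same carbon would give a number closer to that of compound 2. As far as these compounds go, it is also open whether the chloro or the ring nitrogen of the 6-chloropyridin-3-yl group accounts for the gap between compound 2 and the other compounds.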